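A few compounds are considered here, and "the series" means these few. Any claim that something is new, unique, unknown or untested is made for them only; others in the source may bear on it.

Going by the values given here, compound 1 `COc1ccc(-c2nc3cc(F)ccc3s2)cc1` gives 490 nM in a functional assay on MCF7 cells (Homo sapiens) for antiproliferative activity; a higher number here means a weaker inhibitor of growth, a lower number a stronger inhibitor of growth; its number is the lowest of the two measured so far, though the other lies within the scatter. Compound 2 `COc1ccc(-c2nc3cc(F)ccc3s2)cc1Br` gives 850 nM in this assay, and the step of a 1.7-fold higher number from compound 1 to compound 2 (0.24 log units; within the scatter) came from bromo in place of hydrogen on an aromatic carbon. Compound 3 `COc1ccc(-c2nc3cc(F)ccc3s2)cc1O` differs from compound 1 by hydroxy in place of hydrogen on an aromatic carbon. Among the compounds with values here, only the step from compound 1 to compound 2 bears on this change, and it stayed within the scatter, so no step beyond the scatter is expected in this assay. Compound 3 is therefore estimated at 600 nM, with a range of 250 nM to 1500 nM, meaning an expected step of a 1.2-fold higher number from compound 1 to compound 3 (0.09 log units; within the scatter).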

Compound 3, concentration for 50% growth inhibition: 500 nM
The estimate for compound 3 lay 1.2-fold (0.08 log units) above the measured number; the range from low to high includes it.
By their numbers in this assay, from the lowest: compounds 1, 3 and 2 (each within the scatter of the next).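

With a 1.0-fold higher number from compound 1 to compound 3 (0.01 log units; within the scatter) and a 1.7-fold lower number from compound 2 to compound 3 (0.23 log units; within the scatter) in this assay, hydroxy, which brings a hydrogen-bond donor and acceptor, joins bromo at this place ortho to a methoxy group. Two very different replacements for hydrogen have now been tried here, and all three compounds remain within the scatter of one another. Nothing available explains this result. On these data alone, it remains open whether an amine or a carboxylic acid at this place would also stay within the scatter, or whether a larger change would be needed to shift the number.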